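Extending the ketone side chain of a glutamate receptor modulator

The compounds below may be only part of what the source reports. "The series", "measured", "known", "first", "only" and "open" are said of these compounds alone.

Measured so far:
compound 1 `Cc1cc(C(=O)O)ccc1OCCCCOc1ccc(C(=O)CC(C)C)c(O)c1C` with 83.9%
compound 2 `CCC(=O)c1ccc(OCCCCOc2ccc(F)c(C(=O)O)c2)c(C)c1O` with 66.6%

In an assay on HEK293 cells for positive allosteric modulation of metabotropic glutamate receptor 2 (Rattus norvegicus), read by thallium flux, with a stated time of 2.5 min (on this read-out lower numbers stand for smaller maximal responses and higher numbers for larger maximal responses), compound 2 gives 66.6%, the lowest of the two numbers; compound 1, with 83.9%, lies beyond the scatter above it. Compound 3 `Cc1c(OCCCCOc2ccc(F)c(C(=O)O)c2)ccc(C(=O)CC(C)C)c1O` keeps the fluorine-bearing acid of compound 2 and alters the ketone: isopropyl in place of methyl on a saturated chain carbon bound to a carbonyl carbon. For the measured compounds named here, compound 1 carries this same isobutylcarbonyl and gave the higher reading, so an upward step from compound 2 to compound 3 is expected, a number 8.4 percentage points higher from compound 2 to compound 3 (within the scatter), though no step between measured compounds confirms it. Compound 3 is therefore estimated at 75%, within 60% to 90%.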

Compound 3, largest response reached (reported as percent of maximum), in percent of the reference or control that the assay uses: 84.5%
For compound 3 the middle estimate is 9.5 percentage points below the measured one; low and high end bracket the measured number.
By their numbers in this assay, from the lowest: compound 2; then compounds 1 and 3 (each within the scatter of the next).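

In this assay, isopropyl in place of methyl on a saturated chain carbon bound to a carbonyl carbon gives a clear gain (a number 17.9 percentage points higher from compound 2 to compound 3 (beyond the scatter)), so the ketone side chain matters for the maximal response when the fluorine-bearing acid is present. With the isobutylcarbonyl kept, 3-carboxy-4-fluorophenyl in place of 4-carboxy-2-methylphenyl makes no readable difference (a number 0.6 percentage points higher from compound 1 to compound 3 (within the scatter)). Nothing measured here explains either step. From the compounds shown here alone, whether a longer chain such as n-pentyl, or a cyclopropylmethyl group, would hold this response stays open. So does the effect of propanoyl on the 4-carboxy-2-methylphenyl compound.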